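Trimming the Side Chain of a Sulfonyl Amide

This account rests on a few compounds, and the source may have more. Where it says the series, first, only, none or still open, it means among the compounds named here.

Compound 1 `CC(=O)c1ccc(NC(=O)C(C(C)C)N(C(=O)c2ccccc2)S(=O)(=O)c2ccc([N+](=O)[O-])cc2)cc1`: 29.8%
Compound 2 `CCC(C)C(C(=O)Nc1ccc(C(C)=O)cc1)N(C(=O)c1ccccc1)S(=O)(=O)c1ccccc1`: 14.3%

In a functional assay for inhibition, read by spectrophotometry, with a stated time of 20 min, tested at 3 mg/mL (on this read-out lower numbers stand for a weaker effect and higher numbers for a stronger effect at the one concentration tested), compound 2 gives 14.3%, the lowest of the two numbers seen so far, while compound 1 gives 29.8%, a gap that lies beyond the usual scatter. Compound 3 `CC(=O)c1ccc(NC(=O)C(C(C)C)N(C(=O)c2ccccc2)S(=O)(=O)c2ccccc2)cc1` differs from compound 2 in one place: hydrogen in place of methyl on a saturated chain carbon, three bonds along the chain from an amide-type nitrogen and a carbonyl carbon. For the measured compounds named here, with no measured pair showing this change alone, the step is expected to be small, if anything a slight rise that stays within the scatter, as a number 5.7 percentage points higher from compound 2 to compound 3 (within the scatter). Compound 3 is therefore expected to give about 20%, between 6% and 36%.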

Compound 3, a percentage reported as inhibition, at one concentration (the size of the read-out at that concentration, not a potency): 47.5%
For compound 3 the middle estimate is 27.5 percentage points below the measured one; measured number above the stated range.
By their numbers in this assay, from the lowest: compound 2; then compound 1; then compound 3.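

In this assay, sec-butyl giving way to isopropyl proves no minor trim, with a number 33.2 percentage points higher from compound 2 to compound 3 (beyond the scatter) on a chain that differs by a single methyl. With isopropyl kept, hydrogen in place of nitro on an aromatic carbon also counts, as a number 17.7 percentage points higher from compound 1 to compound 3 (beyond the scatter) shows that the nitro group is not required for the effect at this one concentration. Nothing available here accounts for either step. Still open, going by these compounds, is whether a longer chain at the saturated carbon, or an amine in place of nitro on the aromatic carbon, would move the number further.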